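This account rests on a few compounds, and the source may have more. Where it says the series, first, only, none or still open, it means among the compounds named here.

Of the compounds shown here, three have been measured in an assay on isolated protein with Bile acid receptor (Homo sapiens) as the target; a higher number here means that more compound is needed for the effect, a lower number that less compound is needed. Compound 1 `COC(=O)/C=C/c1cccc(N(Cc2ccc(/C=C/c3cc(C(F)(F)F)cc(C(F)(F)F)c3)cc2)C(=O)C2CCCCC2)c1` gives 1470 nM. Compound 2 `COC(=O)/C=C/c1cccc(N(Cc2ccc(/C=C/c3cccc(C(F)(F)F)c3)cc2)C(=O)NC(C)C)c1` gives 932 nM, the second highest of the three numbers; it lies within the scatter of compound 1, while compound 3 `COC(=O)/C=C/c1cccc(N(Cc2ccc(/C=C/c3cccc(F)c3)cc2)C(=O)C2CCCCC2)c1`, which gives 86 nM, lies well below it, beyond the scatter. Compound 4 `COC(=O)/C=C/c1cccc(N(Cc2ccc(/C=C/c3ccc(F)cc3)cc2)C(=O)NC(C)C)c1` is the next compound and has not yet been measured in this assay. It differs from compound 2 by 4-fluorophenyl in place of 3-(trifluoromethyl)phenyl on a double-bonded chain carbon bound to a double-bonded chain carbon. Going by the values given here, no measured pair shows this change in isolation. A modest lowering of the number is expected, since compound 3, which also carries a single fluorine on that ring, gives 86 nM. The estimated step from compound 2 to compound 4 is a 2.3-fold lower number from compound 2 to compound 4 (0.37 log units; beyond the scatter). Compound 4 is therefore expected to give 400 nM, within a range from 100 nM to 1600 nM.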

Compound 4, half-maximal effective concentration: 348 nM
Compound 4: the middle estimate sits 1.1-fold (0.06 log units) above what was measured; the measured number falls inside the stated range.
By their numbers in this assay, from the lowest: compound 3; then compound 4; then compounds 2 and 1 (each within the scatter of the next).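

In this assay, going by these compounds alone, this is the first comparison that isolates a single place: 4-fluorophenyl in place of 3-(trifluoromethyl)phenyl on a double-bonded chain carbon bound to a double-bonded chain carbon gives a 2.7-fold lower number from compound 2 to compound 4 (0.43 log units; beyond the scatter), a modest step beyond the scatter. The number therefore responds to the group at this position. Nothing measured here accounts for the step. Compounds 2 and 4 do not separate losing the trifluoromethyl from placing the fluorine differently, as both change together. On these data alone, how a carboxylic acid in place of the methyl ester would behave also remains open.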